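The compounds below may be only part of what the source reports. "The series", "measured", "known", "first", "only" and "open" are said of these compounds alone.

Compound 1, `CC1(C)CC(N)=Nc2ccc(Cl)cc21`: 81%
Compound 2, `CNC1=Nc2ccc(Cl)cc2C(C)(C)C1`: 92.3%

Among the two numbers measured so far in a functional assay on MDA-MB-231 cells (Homo sapiens) for cytotoxicity, read by MTT assay, with a stated time of 72 h, tested at 5 uM, in the absence of a further agent (on this read-out higher numbers stand for a weaker effect at the one concentration tested and lower numbers for a stronger effect), compound 2 stands highest; its nearest neighbour is compound 1, and the step of a number 11.3 percentage points higher from compound 1 to compound 2 (beyond the scatter) lies beyond the scatter, so that on this read-out compound 2 shows the weaker effect of the two at the single concentration tested.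

Compound 3, `CCNC1=Nc2ccc(Cl)cc2C(C)(C)C1`, is the next member of the series. It differs from compound 2 by methyl in place of hydrogen on a saturated chain carbon bound to an amine nitrogen. Within the data shown here, the only measured step that bears on this change is a number 11.3 percentage points higher from compound 1 to compound 2 (beyond the scatter), where a methyl entered one bond closer in, on the amine nitrogen itself, and the number moved modestly upward. Compound 3 carries the chain one bond further out, from methylamino to ethylamino. With a single step to lean on, the expectation for compound 3 is a small upward movement in this assay, if any, most likely within the scatter: a number 1.7 percentage points higher from compound 2 to compound 3 (within the scatter) is the estimated step. Compound 3 is thus expected to give about 94%, with a range from 80% to 105%.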

Compound 3, a percentage reported as activity, at one concentration (the size of the read-out at that concentration, not a potency): 85.1%
For compound 3 the middle estimate is 8.9 percentage points above the measured one; measured number inside the range.
By their numbers in this assay, from the lowest: compounds 1, 3 and 2 (each within the scatter of the next, the first and the last beyond it).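

In this assay, the change from methylamino to ethylamino comes with one step (a number 7.2 percentage points lower from compound 2 to compound 3 (within the scatter)), and the same ethylamino group set against the unsubstituted amine comes with another (a number 4.1 percentage points higher from compound 1 to compound 3 (within the scatter)). Among these compounds, compound 3 therefore cannot be told apart from either neighbour, and the one step beyond the scatter (a number 11.3 percentage points higher from compound 1 to compound 2 (beyond the scatter)) gains no companion, so neither a trend with chain length nor a lasting effect of substituting this amine nitrogen can be read from the three compounds. Nothing at hand explains these numbers.

From the compounds shown here alone, a propyl or longer chain, a branched chain such as isopropyl, and a cyclic group such as cyclopropyl on the same amine nitrogen remain open, as does an acetyl group there, so it is unknown whether any of these would move the number clearly away from those of compound 1 and compound 2. With only one concentration tested, these compounds also leave open how the three would compare over a range of concentrations.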